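The source may hold more compounds than are shown below. What is called first, only, known or untested is meant among the compounds shown, and "the series" means these compounds.

Measured compounds in an assay on isolated protein for inhibition of serine/threonine-protein kinase TNNI3K (Homo sapiens); on this read-out lower numbers stand for stronger inhibition and higher numbers for weaker inhibition:
compound 1 `O=C(Nc1ccc(Oc2ccncn2)cc1)Nc1cccc(C(F)(F)F)c1` gives 160 nM
compound 2 `CNc1nccc(Oc2ccc(NC(=O)Nc3cccc(C(F)(F)F)c3)cc2)n1` gives 50 nM

Among the compounds with values here, compound 2 holds the lower of the two numbers in this assay; the only other compound, compound 1, stands apart by a 3.2-fold lower number from compound 1 to compound 2 (0.51 log units; beyond the scatter). The structural change between these two compounds is a methylamino in place of hydrogen on an aromatic carbon of the core.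

Compound 3 `O=C(Nc1ccc(Oc2ccncc2)cc1)Nc1cccc(C(F)(F)F)c1` is the next variation on the shared core. Its difference from compound 2 is pyridin-4-yl in place of 2-(methylamino)pyrimidin-4-yl on an oxygen on an aromatic ring. Two things happen at once: the methylamino is lost again, and the ring bearing it is exchanged. Only the first part has a measured precedent, namely a 3.2-fold lower number from compound 1 to compound 2 (0.51 log units; beyond the scatter), which means a loss of the methylamino should send the number back upward by roughly that amount. Within the data shown here, the ring exchange from pyrimidine to pyridine has no counterpart among the two measured compounds, so its contribution is an open question and widens the range.

For compound 3 the expectation is therefore a 3.6-fold higher number from compound 2 to compound 3 (0.56 log units; beyond the scatter), landing near compound 1. Compound 3 is estimated at 180 nM, within 60 nM to 550 nM.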

Compound 3, half-maximal inhibitory concentration: 50 nM
Compound 3: middle estimate off by 3.6-fold (0.56 log units), on the high side; measured number outside the range, below it.
By their numbers in this assay, from the lowest: compounds 2 and 3 (each within the scatter of the next); then compound 1.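

In this assay, pyridin-4-yl in place of pyrimidin-4-yl on the oxygen gives a 3.2-fold lower number from compound 1 to compound 3 (0.51 log units; beyond the scatter), so the ring exchange alone, with no methylamino present, produces a step of the same printed size as a 3.2-fold lower number from compound 1 to compound 2 (0.51 log units; beyond the scatter). Pyridin-4-yl in place of 2-(methylamino)pyrimidin-4-yl gives no change at the digits printed from compound 2 to compound 3 (within the scatter), so at this position the methylamino group is not required to reach the level of compound 2, and two different changes to compound 1 end within the scatter of each other. No supporting data bear on why these two changes arrive at the same level.

Still open, going by these compounds, is whether the two steps add up, which a 2-(methylamino)pyridin-4-yl on the same oxygen would test directly in this assay. Also open, on these data alone, is how the number responds at this position when the methylamino is replaced on the pyrimidine or added to the pyridine as a plain amino group, an ethylamino group or a longer chain on the amine.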